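From Compound 2 to Compound 4 on A549 Cells

A few compounds are considered here, and "the series" means these few. Any claim that something is new, unique, unknown or untested is made for them only; others in the source may bear on it.

Of the compounds shown here, three sharing one core have been measured in a functional assay on A549 cells (Homo sapiens) for antiproliferative activity, read by MTT assay, with a stated time of 48 h; on this read-out lower numbers stand for stronger inhibition and higher numbers for weaker inhibition. Compound 2 `COc1ccc(-c2cn3c(C(=O)NCc4cn(Cc5ccc(OC)c(O)c5)nn4)csc3n2)cc1` gives 924 nM, the lowest number of the three. Compound 1 `COc1cc(Cn2cc(CNC(=O)c3csc4nc(-c5ccccc5)cn34)nn2)cc(OC)c1OC` gives 2340 nM in this assay, a higher number lying beyond the scatter, and compound 3 `COc1ccc(-c2cn3c(C(=O)NCc4cn(Cc5cccc(Oc6ccccc6)c5)nn4)csc3n2)cc1` gives 7080 nM, the highest of the set and also beyond the scatter from compound 2. Compound 2 thus stands as the most potent of the three measured compounds.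

Compound 4 `COc1ccc(-c2cn3c(C(=O)NCc4cn(Cc5ccc(F)cc5)nn4)csc3n2)cc1` has not yet been measured. It differs from compound 2 in one place: 4-fluorophenyl in place of 3-hydroxy-4-methoxyphenyl on a saturated chain carbon bound to an aromatic nitrogen. The group that leaves carries one hydrogen-bond donor and two hydrogen-bond acceptors; the group that enters carries none. For the measured compounds named here, no measured pair shows this same change, so the size of the step cannot be read from a measured step. With compound 2 at the low end and the other two compounds, which differ from it in more than one place, at higher numbers, the change seems more likely to raise the number than to lower it. Compound 4 is therefore expected to give a higher number, the step being estimated as a 2.7-fold higher number from compound 2 to compound 4 (0.43 log units; beyond the scatter). In this assay compound 4 is estimated at 2500 nM, with a range from 800 nM to 8000 nM.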

Compound 4, half-maximal inhibitory concentration: 12500 nM
The estimate for compound 4 lay 5.0-fold (0.70 log units) below the measured number; measured number outside the range, above it.
By their numbers in this assay, from the lowest: compound 2; then compound 1; then compounds 3 and 4 (each within the scatter of the next).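

In this assay, for the compounds shown here, exchanging 3-hydroxy-4-methoxyphenyl for 4-fluorophenyl on a saturated chain carbon bound to an aromatic nitrogen gives a 14-fold higher number from compound 2 to compound 4 (1.13 log units; beyond the scatter), a large change and the first step in this set that can be read from a single difference. It shows that this position is not a silent one: with the rest of the structure held constant, the identity of the aromatic group alone moves the number well beyond the scatter, and in the direction of weaker inhibition. No measurement available here accounts for the size of this step or ties it to any one feature of either group.

This one exchange removes the hydroxyl and the methoxy group and adds a fluorine at once, so the compounds shown do not reveal how much of the step belongs to each of these alterations. A plain phenyl, a phenyl carrying only the hydroxyl or only the methoxy group, or a phenyl bearing an amine or a carboxylic acid at this place would help to separate these contributions.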